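The source may hold more compounds than are shown below. What is called first, only, known or untested is meant among the compounds shown, and "the series" means these compounds.

Compound 3 (`O=c1ccn(C2[Se][C@H](CO)[C@@H](O)[C@@H]2O)c(=O)[nH]1`) was tested in a functional assay on PC-3 cells (Homo sapiens) for cytotoxicity, read by sulforhodamine B assay; a higher number here means a weaker inhibitor, a lower number a stronger inhibitor. In this assay compound 3 gives only a limit, > 100000 nM, and not a number. Two close relatives are compound 1 (`[N-]=[N+]=N[C@@H]1C(n2ccc(=O)[nH]c2=O)[Se][C@H](CO)[C@H]1O`) and compound 2 (`Cc1cn(C2[Se][C@H](CO)[C@@H](O)[C@@H]2N=[N+]=[N-])c(=O)[nH]c1=O`). In this assay compound 1 also gives only a limit, > 100000 nM. Compound 2 gives a limit as well, > 100000 nM. Because every value sits at the limit of > 100000 nM in this assay, at which 3 of the 3 values shown sit, neither a step that the two limits leave unreadable from compound 1 to compound 2 nor a step that the two limits leave unreadable from compound 1 to compound 3 can be given a size. Compound 4 (`Cc1cn(C2[Se][C@H](CO)[C@@H](O)[C@@H]2O)c(=O)[nH]c1=O`) differs from compound 3 by methyl in place of hydrogen on an aromatic carbon. The same exchange, methyl in place of hydrogen on an aromatic carbon, is the change whose measured step is a step that the two limits leave unreadable from compound 1 to compound 2, which left no readable size. No measured value here gives a reason to expect a number rather than a limit for compound 4. Compound 4 is therefore expected to show 150000 nM, within a range from 50000 nM to 1000000 nM. The step this estimate means, a step that the limit leaves unreadable from compound 3 to compound 4, is expected to be none beyond the scatter.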

Compound 4, half-maximal inhibitory concentration: > 100000 nM
Compound 4 gave a limit, no number; the forecaster's own chance of this, stated with the estimate: 90%; the middle value is on the limit's open side.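

In this assay compound 4 gives > 100000 nM, a limit and not a number. Its steps from compound 2 and compound 3 therefore cannot be read: the limit of > 100000 nM in this assay, at which 4 of the 4 values shown sit.

With no number among them, the compounds shown leave open whether methyl in place of hydrogen or hydroxy in place of azido changes cytotoxicity at all.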